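Replacing the Methoxyphenyl Hydrazone Aryl with a Dihydroxyphenyl

The source may hold more compounds than are shown below. What is called first, only, known or untested is meant among the compounds shown, and "the series" means these compounds.

Compound 1, `CN(C)CCn1cnnc1-c1cc(Oc2ccc(NC(=O)N/N=C/c3c(O)ccc4ccccc34)cc2F)ccn1`: in a functional assay on U-87MG ATCC cells (Homo sapiens) for cytotoxicity, read by MTT assay, with a stated time of 72 h (a lower number here means a stronger inhibitor, a higher number a weaker inhibitor), compound 1 gives 620 nM.
Compound 2, `COc1ccc(/C=N/NC(=O)Nc2ccc(Oc3ccnc(-c4nncn4CCN(C)C)c3)c(F)c2)cc1O`: in this assay compound 2 is reported only as a limit, > 100000 nM.

Compound 2 stands at the limit of this assay; (the limit of > 100000 nM in this assay, at which 1 of the 2 values shown sits). Within the data shown here, its structure differs from compound 1 in one place, and that step, an at least 160-fold higher number from compound 1 to compound 2 (2.20 log units; beyond the scatter), is the only measured step in the set. Compound 3, `CN(C)CCn1cnnc1-c1cc(Oc2ccc(NC(=O)N/N=C/c3ccc(O)cc3O)cc2F)ccn1`, changes compound 2 at the same carbon: 2,4-dihydroxyphenyl in place of 3-hydroxy-4-methoxyphenyl on a carbon with a double bond to nitrogen. Among the measured compounds shown here, no measured step covers this exact exchange. For the measured compounds named here, the only bearing comparison is that compound 1, carrying 2-hydroxynaphthalen-1-yl at that carbon, gives 620 nM. Compound 2, by contrast, sits at the limit. A move back toward a lower number is therefore plausible for compound 3, though its size is uncertain. Compound 3 is expected to show 20000 nM (range 3000 nM to 100000 nM) in this assay. This estimate corresponds to an expected step of an at least 5.0-fold lower number from compound 2 to compound 3 (0.69 log units; beyond the scatter).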

Compound 3, half-maximal inhibitory concentration: 15400 nM
Compound 3: middle estimate off by 1.3-fold (0.11 log units), on the high side; low and high end bracket the measured number.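

With the 2,4-dihydroxyphenyl group on this carbon, compound 3 returns a measured value in this assay, showing that a hydrazone aryl with one six-membered ring need not sit at the limit: the step is an at least 6.4-fold lower number from compound 2 to compound 3 (0.81 log units; beyond the scatter). The size of that step is only a lower bound, as one end of it is a limit: the limit of > 100000 nM in this assay, at which 1 of the 3 values shown sits. The same ring still falls well short of the 2-hydroxynaphthalen-1-yl group, with a 25-fold higher number from compound 1 to compound 3 (1.40 log units; beyond the scatter).

Going by these compounds, whether the change comes from losing the methoxy group or from the placing of the hydroxyl groups stays open, since 2,4-dihydroxyphenyl differs from 3-hydroxy-4-methoxyphenyl in both respects. Also open, on these data alone, is how a naphthalene without the hydroxyl group, or a phenyl ring carrying an amine or a carboxylic acid, would behave on this carbon.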